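Swapping Fluoro for Methoxy on the Pendant Phenyl Ring

The source may report more compounds than this note shows. Statements on the series, on what has been measured and on what is new or still open speak of the compounds shown alone.

Compound 1 `COc1cc(-n2cnc3ccc(-c4ccc(C)cc4F)cc32)cc(OC)c1OC`: 5650 nM
Compound 2 `COc1cc(-n2cnc3ccc(-c4cccc(O)c4)cc32)cc(OC)c1OC`: 53 nM
Compound 3 `COc1cc(-n2cnc3ccc(-c4cccc(F)c4)cc32)cc(OC)c1OC`: 2490 nM

All three compounds share one core and were tested in a functional assay on SGC-7901 cells (Homo sapiens) for antiproliferative activity, read by MTT assay, with a stated time of 72 h; a lower number here means a stronger inhibitor, a higher number a weaker inhibitor. Among the three numbers, compound 3 stands second highest. Above it sits compound 1, and the change from that compound gives a 2.3-fold lower number from compound 1 to compound 3 (0.36 log units; beyond the scatter). Far below it sits compound 2; going the other way, the change gives a 47-fold higher number from compound 2 to compound 3 (1.67 log units; beyond the scatter), and from compound 1 the hydroxy analogue gives a 110-fold lower number from compound 1 to compound 2 (2.03 log units; beyond the scatter).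

Compound 4 `COc1cccc(-c2ccc3ncn(-c4cc(OC)c(OC)c(OC)c4)c3c2)c1` differs from compound 3 by methoxy in place of fluoro on an aromatic carbon. Among the measured compounds shown here, the one step that bears directly on this is a 47-fold higher number from compound 2 to compound 3 (1.67 log units; beyond the scatter), which shows that at this position hydroxy gave a far lower number than fluoro. Methoxy brings one hydrogen-bond acceptor, as counted, but the data do not show whether an acceptor alone recovers what hydroxy gave in compound 2. A lowering is expected, but smaller than that large step. Compound 4 is therefore expected to give 800 nM in this assay, within 150 nM to 4000 nM. The expected step from compound 3 is a 3.1-fold lower number from compound 3 to compound 4 (0.49 log units; beyond the scatter).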

Compound 4, half-maximal inhibitory concentration: 3310 nM
Compound 4: the middle estimate sits 4.1-fold (0.62 log units) below what was measured, and the stated range covers the measured number.
By their numbers in this assay, from the lowest: compound 2; then compounds 3, 4 and 1 (each within the scatter of the next, the first and the last beyond it).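

In this assay, exchanging fluoro for methoxy at this place on the pendant ring leaves the reading within the scatter (a 1.3-fold higher number from compound 3 to compound 4 (0.12 log units; within the scatter)), so the added oxygen, counted as a hydrogen-bond acceptor, brings no measurable gain here. The more telling comparison is with the hydroxy compound: putting a methyl on that oxygen, and so removing only its hydrogen, has a large effect (a 62-fold higher number from compound 2 to compound 4 (1.80 log units; beyond the scatter)), which shows that an oxygen at this place is not enough to keep the low number of compound 2. The 3-methoxyphenyl group also cannot be separated from the 2-fluoro-4-methylphenyl group (a 1.7-fold lower number from compound 1 to compound 4 (0.23 log units; within the scatter)), so among these compounds only the 3-hydroxyphenyl group stands clearly apart.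

Nothing measured here explains why the hydrogen on that oxygen matters so much. Going by these compounds, it also remains open whether an amine or a carboxylic acid at the same place on the ring would give a number close to that of compound 2, or would fall back with compound 3 and compound 4.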